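Guanosine-type series: ester to amino alcohol at the chain

The source may hold more compounds than are shown below. What is called first, only, known or untested is meant among the compounds shown, and "the series" means these compounds.

Three compounds of one shared core have numbers in a functional assay (B cells) with Mus musculus as the target; a higher number here means that more compound is needed for the effect, a lower number that less compound is needed. Compound 1 `CCOC(=O)Cn1c(=O)n(C2OC(CO)[C@@H](O)[C@H]2O)c2nc(N)nc(O)c21` gives 48 uM in this assay and stands second highest of the three. Compound 2 `C=CCSc1nc2c(O)nc(N)nc2n1C1OC(CO)[C@@H](O)[C@H]1O`, with 107 uM, is its nearest neighbour and sits higher, beyond the scatter. Among the compounds with values here, compound 3 `C=CCn1c(=S)n(C2OC(CO)[C@@H](O)[C@H]2O)c2nc(N)nc(O)c21`, at 1 uM, lies far lower than the other two; compound 3 is the one that needs least compound, and its gap to compound 1 is the widest in the set.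

Compound 4 `NCC(O)Cn1c(=O)n(C2OC(CO)[C@@H](O)[C@H]2O)c2nc(N)nc(O)c21` is not yet measured. It differs from compound 1 in one place: 2-amino-1-hydroxyethyl in place of ethoxycarbonyl on a saturated chain carbon bound to an aromatic nitrogen. The group that leaves carries no hydrogen-bond donor; the group that enters carries two, while the count of acceptors is unchanged. Within the data shown here, no measured pair in the set isolates this kind of change, so nothing among the three numbers speaks directly for its size or direction.

Expectation for compound 4 in this assay: a step from compound 1 that is small, most likely none beyond the scatter, with a slight lean toward a lower number, expressed as a 1.4-fold lower number from compound 1 to compound 4 (0.14 log units; within the scatter). Compound 4 is estimated at 35 uM, within a range from 10 uM to 120 uM.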

Compound 4, concentration for half-maximal effect: 28 uM
Beside the measured number, compound 4's estimate is 1.3-fold (0.10 log units) above it; low and high end bracket the measured number.
By their numbers in this assay, from the lowest: compound 3; then compounds 4 and 1 (each within the scatter of the next); then compound 2.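

In this assay, within the data shown here, 2-amino-1-hydroxyethyl in place of ethoxycarbonyl on a saturated chain carbon bound to an aromatic nitrogen gives a 1.7-fold lower number from compound 1 to compound 4 (0.23 log units; within the scatter), the first step that can be read at this position. The position therefore tolerates this exchange without a shift beyond the scatter: ethoxycarbonyl leaves with its double bond, and hydrogen-bond donors enter where the leaving group has none, yet the read-out does not separate the two compounds. No supporting measurement bears on this result, so the step stands as an observation only.

The compounds shown leave open which part of the 3-amino-2-hydroxypropyl chain matters, if either does, since the amine and the hydroxyl enter together and a chain carrying only a primary amine or only a hydroxyl would be needed to separate them. Also open, going by these compounds, are how a free carboxylic acid in place of ethoxycarbonyl or a longer chain would read at this position, and whether the same exchange holds on the thiocarbonyl form of the core seen in compound 3.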